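The source may hold more compounds than are shown below. What is called first, only, known or untested is meant among the compounds shown, and "the series" means these compounds.

Measured in a functional assay on Caco-2 cells (Homo sapiens) for inhibition, read by MTT assay, with a stated time of 48 h; a higher number here means a weaker inhibitor of growth, a lower number a stronger inhibitor of growth:
- compound 1 `CN1CC[C@H](c2c(O)cc(O)c3c(=O)cc(/C=C/c4ccc(Cl)cc4)oc23)[C@H](O)C1`: 5600 nM
- compound 2 `CN1CC[C@H](c2c(O)cc(O)c3c(=O)cc(/C=C/c4c(F)c(F)c(F)c(F)c4F)oc23)[C@H](O)C1`: 8000 nM

Among the measured compounds shown here, compound 1 has only one measured neighbour in this assay, and the two values lie within the scatter of each other: a 1.4-fold higher number from compound 1 to compound 2 (0.15 log units; within the scatter). The two compounds therefore cannot be ranked on these numbers.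

The unmeasured compound 3 `CN1CC[C@H](c2c(O)cc(O)c3c(=O)cc(/C=C/c4ccccc4Cl)oc23)[C@H](O)C1` keeps the core of compound 1 and changes only the aryl group: 2-chlorophenyl in place of 4-chlorophenyl on a double-bonded chain carbon bound to a double-bonded chain carbon. Compounds 1 and 3 have the same atoms, joined differently, with 2-chlorophenyl in place of 4-chlorophenyl.

For the measured compounds named here, only one measured step bears on this change. It alters the group at the same place, on a double-bonded chain carbon bound to a double-bonded chain carbon, and its size stays within the scatter: a 1.4-fold higher number from compound 1 to compound 2 (0.15 log units; within the scatter). Going by the values given here, no measured compound carries 2-chlorophenyl, so this single step is weak support. Even so, it gives no ground to expect a real shift in either direction.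

The expected change is a 1.1-fold higher number from compound 1 to compound 3 (0.03 log units; within the scatter), which is no step beyond the scatter. Compound 3 is estimated at 6000 nM, with an expected range of 2800 nM to 13000 nM.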

Compound 3, concentration for 50% growth inhibition: 9000 nM
The estimate for compound 3 lay 1.5-fold (0.18 log units) below the measured number, within the range that was stated.
By their numbers in this assay, from the lowest: compounds 1, 2 and 3 (each within the scatter of the next).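

In this assay, the change keeps the atoms of the group and alters only how they are joined, and it gives a 1.6-fold higher number from compound 1 to compound 3 (0.21 log units; within the scatter), so these two chlorophenyl isomers cannot be told apart at this place on the double-bonded chain carbon. The exchange of 2,3,4,5,6-pentafluorophenyl for 2-chlorophenyl gives a 1.1-fold higher number from compound 2 to compound 3 (0.05 log units; within the scatter), which completes the set: all three pairs now lie within the scatter, and this holds for the three aryl groups shown, with no compound going against it. No supporting measurement is available that could account for this lack of separation.

Open, going by these compounds, is whether any group at this place can give a step beyond the scatter, for example an unsubstituted phenyl, a phenyl carrying an amine or a carboxylic acid, or a pyridine ring in place of the phenyl. The three compounds share one core and one chain, so they also say nothing about a longer chain between the core and the aryl group, or about the effect of any change away from this place.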